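The source may report more compounds than this note shows. Statements on the series, on what has been measured and on what is new or still open speak of the compounds shown alone.

In a physicochemical assay for solubility, using the shake flask method, in simulated intestinal fluid, measured as kinetic solubility, with a stated time of 2 h, at 25 degrees C, at pH 6.5 (on this read-out higher numbers stand for higher solubility and lower numbers for lower solubility), three compounds sharing one core have been measured. Compound 1 `Cc1nc(C#N)c(N)c2c1C(=O)N(Cc1ccccc1)C2=O` gives < 5000 nM, which is a limit of the assay and not a number. Compound 2 `COC(=O)c1nc(C)c2c(c1N)C(=O)N(Cc1ccccc1)C2=O` gives 7400 nM. Compound 3 `Cc1nc(C(N)=O)c(N)c2c1C(=O)N(Cc1ccccc1)C2=O` gives < 5000 nM, which is also only a limit. Compound 4 `Cc1nc(C(=O)NC#N)c(N)c2c1C(=O)N(Cc1ccccc1)C2=O` changes compound 3 by putting cyano in place of hydrogen on an amide-type nitrogen. Among the compounds with values here, no measured step makes this exact change, but the nearest ones alter the same substituent. They are an at least 1.4-fold higher number from compound 1 to compound 2 (0.17 log units; that floor lies within the scatter), an at least 1.4-fold lower number from compound 2 to compound 3 (0.17 log units; that floor lies within the scatter) and a step that the two limits leave unreadable from compound 1 to compound 3. None of these shows a readable step beyond the scatter, so only a small rise is expected, and an at least 1.3-fold higher number from compound 3 to compound 4 (0.11 log units; that floor lies within the scatter) is the estimated step. For compound 4 the expected solubility is 6500 nM, with an estimated range of 2500 nM to 20000 nM.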

Compound 4, solubility: 185000 nM
The estimate for compound 4 lay 28-fold (1.45 log units) below the measured number; measured number outside the range, above it.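

In this assay cyano in place of hydrogen on the amide-type nitrogen gives an at least 37-fold higher number from compound 3 to compound 4 (1.56 log units; beyond the scatter); unlike every earlier step at this substituent, it lies beyond the scatter. Cyanoamino in place of methoxy on the carbonyl carbon gives a 25-fold higher number from compound 2 to compound 4 (1.40 log units; beyond the scatter), and cyanocarbamoyl in place of cyano on the aromatic carbon gives an at least 37-fold higher number from compound 1 to compound 4 (1.56 log units; beyond the scatter). Compound 1 and compound 3 each give only a limit and not a number, so the steps from them are floors: the limit of < 5000 nM in this assay, at which 2 of the 4 values shown sit.

The compounds shown leave open whether a methyl or an acetyl on this same nitrogen would give a step of similar size. They also leave open how a carboxylic acid in place of the whole cyanocarbamoyl group would compare.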